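The compounds below may be only part of what the source reports. "The series", "measured", "known", "first", "only" and "open" are said of these compounds alone.

Three compounds have been measured so far in an ADME assay on BJ cells (Homo sapiens) for cytotoxicity, with a stated time of 72 h (on this read-out lower numbers stand for an effect already at smaller amounts and higher numbers for an effect only at larger amounts of compound), as follows:

- Compound 1 (`C=C[C@@](C)(/C=C/c1ccc(O)c(/C=C/c2ccc(Cl)c(Cl)c2)c1)CCC=C(C)C`) gives > 13000 nM as a limit
- Compound 2 (`COc1ccc(/C=C/[C@@](C)(/C=C/c2ccc(O)cc2)CCC=C(C)C)cc1`) gives > 36600 nM as a limit
- Compound 3 (`CC(C)=CCC[C@@](C)(/C=C/c1ccccc1)/C=C/c1ccc(O)cc1`) gives > 36600 nM as a limit

None of these values is a number in the full sense, since each is a limit of the assay. Compound 3 has no exact position: it stands at the limit of > 36600 nM in this assay, at which 2 of the 3 values shown sit, and that is a limit. Compound 1 stands at the limit of > 13000 nM in this assay, at which 1 of the 3 values shown sits, and that too is a limit.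

Compound 4 (`CC(C)=CCC[C@](C)(/C=C/c1ccc(O)cc1)/C=C/c1cccc(F)c1`) is compound 3 with fluoro in place of hydrogen on an aromatic carbon, so that phenyl becomes 3-fluorophenyl. The nearest measured change is also made on an aromatic carbon, with hydrogen in place of methoxy. It is a step that the two limits leave unreadable from compound 2 to compound 3 and gives no size to carry over. No step beyond the scatter is therefore expected in this assay, and no direction can be assigned. Compound 4 may well be reported only as a limit again. The expected change is a step that the limit leaves unreadable from compound 3 to compound 4 on this estimate. For compound 4 the estimated value is 45000 nM with an expected range from 20000 nM to 100000 nM in this read-out.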

Compound 4, half-maximal effective concentration: > 36600 nM
Compound 4: no number, only a limit (the forecaster's own chance of this, stated with the estimate: 85%); the middle value is on the limit's open side.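

Compound 4, like compound 3 and compound 2, is reported only as a limit in this assay, so no step can be read from compound 3 to compound 4 or from compound 2 to compound 4. The compounds shown leave open what fluoro in place of hydrogen on the aromatic carbon does to the read-out of this assay.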